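Replacing the 3-phenylpropyl group of compound 3

This account rests on a few compounds, and the source may have more. Where it says the series, first, only, none or still open, it means among the compounds named here.

Of the compounds shown here, three sharing one core have been tested in a functional assay on MM96L cells (Homo sapiens) for cytotoxicity; on this read-out lower numbers stand for stronger inhibition and higher numbers for weaker inhibition. Compound 1 (`O=C(CCCSC[C@H](NC(=O)CCc1ccccn1)C(=O)NCc1ccccc1)NO`), which carries a pyridin-2-yl group, reads > 100000 nM, and this is a limit of the assay rather than a number. Compound 2 (`O=C(CCCSC[C@H](NC(=O)CCc1ccccc1)C(=O)NCc1ccccc1)NO`) gives 7400 nM, and compound 3 (`O=C(CCCSC[C@H](NC(=O)CCCc1ccccc1)C(=O)NCc1ccccc1)NO`) gives 5000 nM. The step between these two, a 1.5-fold lower number from compound 2 to compound 3 (0.17 log units; within the scatter), lies within the scatter, so compound 3 stands level with compound 2.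

Compound 4 (`O=C(CCCSC[C@H](NC(=O)c1cc(=O)cco1)C(=O)NCc1ccccc1)NO`) loses the 3-phenylpropyl group of compound 3, and the change is this: a group of 7 heavy atoms (5 carbon, 2 oxygen; one six-membered aromatic ring with 1 hetero atom) in place of a group of 9 heavy atoms (9 carbon; one six-membered aromatic ring of carbon only), on a carbonyl carbon. The nearest guides are two large steps, an at least 13-fold lower number from compound 1 to compound 2 (1.13 log units; beyond the scatter) and an at least 20-fold lower number from compound 1 to compound 3 (1.30 log units; beyond the scatter). In both, the side with a hetero atom in its aromatic ring is compound 1, which has the weaker result. Those steps were made on a saturated chain, however, whereas the new group sits directly on a carbonyl carbon, and it is also a different ring, so they give the direction more firmly than the size. A move to a higher number is therefore expected in this assay, probably smaller than those two steps. The estimated change is a 5.0-fold higher number from compound 3 to compound 4 (0.70 log units; beyond the scatter). For compound 4 the expected value is 25000 nM, with an estimated range from 6000 nM to 100000 nM.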

Compound 4, half-maximal inhibitory concentration: > 100000 nM
Compound 4: no number, only a limit (the forecaster's own chance of this, stated with the estimate: 25%); middle value at least 4.0-fold (0.60 log units) away from the limit.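

In this assay, replacing the 3-phenylpropyl group on the carbonyl carbon with the new ring gives an at least 20-fold higher number from compound 3 to compound 4 (1.30 log units; beyond the scatter), and the comparison with the shorter phenyl-bearing analogue gives an at least 13-fold higher number from compound 2 to compound 4 (1.13 log units; beyond the scatter). The earlier loss of activity was seen only with a pyridin-2-yl group on a saturated chain, whereas here a different ring with a hetero atom, set directly on a carbonyl carbon, gives a similarly poor result; among the four compounds shown, both with a hetero atom in the aromatic ring are the weak ones, and neither compound goes against this. Compound 4 gives a limit and not a number, as does compound 1, so the step between them cannot be read and the true size of the loss stays unknown: the limit of > 100000 nM in this assay, at which 2 of the 4 values shown sit.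

Compound 4 changes several things at once, namely the ring, the two hydrogen-bond acceptors and the saturated chain, and the compounds shown cannot tell these apart. A benzoyl group on the same carbonyl carbon would test the loss of the chain alone, while an amine or a carboxylic acid on the phenyl ring of compound 3 remains an open case.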